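Shared core series: methylsulfonyl in place of trifluoromethyl

The compounds below may be only part of what the source reports. "The series", "measured", "known", "first", "only" and "open" are said of these compounds alone.

Compound 2 `Oc1nc2ccc(C(F)(F)F)cc2c(O)c1-c1ccccc1` carries a trifluoromethyl group on the shared core. In an assay on isolated protein for inhibition of fatty acid synthase (Rattus norvegicus) (a higher number here means a weaker inhibitor, a lower number a stronger inhibitor), compound 2 gives only a limit, > 15000 nM. Compound 1 `N#Cc1ccc2nc(O)c(-c3ccccc3)c(O)c2c1` has no result in this assay ("not determined" (no result reported)). So compound 2 stands at the limit of > 15000 nM in this assay, at which 1 of the 2 values shown sits, with no numeric partner, and no step between measured compounds exists. Compound 3 `CS(=O)(=O)c1ccc2nc(O)c(-c3ccccc3)c(O)c2c1` differs by methylsulfonyl in place of trifluoromethyl on an aromatic carbon. In this assay the expected step is a step that the limit leaves unreadable from compound 2 to compound 3, which is no movement beyond the scatter. Compound 3 is estimated at 20000 nM, within 5000 nM to 80000 nM, and most probably again only a limit.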

Compound 3, half-maximal inhibitory concentration: > 15000 nM
Compound 3: only a limit was reported; the forecaster's own chance of this, stated with the estimate: 70%; the middle value lies beyond the limit too.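

For the compounds shown here, compound 2 and compound 3 are both reported only as limits in this assay, so no step between them can be read. The compounds shown leave open whether trifluoromethyl and methylsulfonyl differ at all in this assay.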